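The source may report more compounds than this note shows. Statements on the series, on what has been measured and on what is new or still open speak of the compounds shown alone.

Measured so far in an ADME assay on LLC-PK1 cells (Sus scrofa) for permeability; on this read-out lower numbers stand for lower permeability and higher numbers for higher permeability:
- compound 1 `COC[C@]12C[C@H]1[C@@](C)(c1cc(NC(=O)c3ccc(OCC(F)(F)F)cn3)cc(F)c1F)N=C(N)S2` gives 18 10^-6 cm/s
- compound 2 `C#CCOc1ccc(C(=O)Nc2cc(F)c(F)c([C@@]3(C)N=C(N)S[C@@]4(COC)C[C@H]43)c2)nc1` gives 14 10^-6 cm/s
- compound 3 `COC[C@]12C[C@H]1[C@@](C)(c1cc(NC(=O)c3cnc(OCC(F)(F)F)cn3)cc(F)c1F)N=C(N)S2` gives 25 10^-6 cm/s

Compound 3, at 25 10^-6 cm/s in this set, lies within the usual scatter of both other compounds, so the three cannot be ranked. Compound 4 `COC[C@]12C[C@H]1[C@@](C)(c1cc(NC(=O)c3cnc(OCc4ncco4)cn3)cc(F)c1F)N=C(N)S2` differs from it in one place, with 1,3-oxazol-2-yl in place of trifluoromethyl on a saturated chain carbon bound to an oxygen on an aromatic ring. This turns 2,2,2-trifluoroethoxy into (1,3-oxazol-2-yl)methoxy. For the measured compounds named here, the only measured change at this place puts ethynyl in place of trifluoromethyl (a 1.3-fold lower number from compound 1 to compound 2 (0.11 log units; within the scatter)), a small step. One step with a different incoming group is thin guidance, so only a modest drop, not beyond the scatter, is expected (a 1.6-fold lower number from compound 3 to compound 4 (0.19 log units; within the scatter)). In this assay, the estimated value for compound 4 is 16 10^-6 cm/s (expected range 9 10^-6 cm/s to 26 10^-6 cm/s).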

Compound 4, apparent permeability: 48 10^-6 cm/s
Beside the measured number, compound 4's estimate is 3.0-fold (0.48 log units) below it; the measured number lies above the stated range.
By their numbers in this assay, from the lowest: compounds 2, 1, 3 and 4 (each within the scatter of the next, the first and the last beyond it).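

In this assay, putting 1,3-oxazol-2-yl in place of trifluoromethyl gives a 1.9-fold higher number from compound 3 to compound 4 (0.28 log units; within the scatter), so the two compounds cannot be told apart. The earlier step at this place brought in only ethynyl, whereas this one shows that a five-membered aromatic ring with 2 hetero atoms can stand here with a number inside the scatter of the trifluoromethyl compound. Nothing shown explains this result. Still open, from the compounds shown here alone, is how an amine or a carboxylic acid on this saturated chain carbon would read in this assay. Going by these compounds, a longer chain between the oxygen and the 1,3-oxazol-2-yl ring is equally open.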